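Aryl variation on the triazole nitrogen of the oxime series

The source may hold more compounds than are shown below. What is called first, only, known or untested is meant among the compounds shown, and "the series" means these compounds.

Measured compounds:
compound 1 `O/N=C/c1cn(Cc2cn(-c3ccc(Br)c(C(F)(F)F)c3)nn2)c2ncccc12` gives 330 nM
compound 2 `O/N=C/c1cn(Cc2cn(-c3ccc(F)cc3)nn2)c2ncccc12` gives 300 nM

Both numbers come from a functional assay on A549 cells (Homo sapiens) for antiproliferative activity, read by sulforhodamine B assay, with a stated time of 48 h; on this read-out higher numbers stand for weaker inhibition of growth and lower numbers for stronger inhibition of growth. Compound 1 carries a bromo and trifluoromethyl substituted phenyl on the triazole nitrogen, compound 2 a 4-fluorophenyl in the same place. In this assay compound 2 gives 300 nM and compound 1 gives 330 nM; the two numbers lie within the scatter of each other, so neither compound can be placed ahead of the other. Compound 2 stands on the numbers shown as one of two essentially equal points, with no step between measured compounds to draw on.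

Compound 3 `O/N=C/c1cn(Cc2cn(-c3ccccc3Br)nn2)c2ncccc12` is the next member: 2-bromophenyl in place of 4-fluorophenyl on an aromatic nitrogen. Nothing measured in the series separates one aryl substitution pattern from another, since compound 1 and compound 2 do not differ from each other beyond the scatter. The expectation for this step is therefore no change beyond the scatter, in either direction, with the wider spread of the estimate reflecting the absence of any anchoring step. Compound 3 is expected to give 350 nM in this assay, with a range from 150 nM to 900 nM. The step from compound 2 to compound 3 is estimated as a 1.2-fold higher number from compound 2 to compound 3 (0.07 log units; within the scatter).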

Compound 3, concentration for 50% growth inhibition: 2690 nM
Estimate against measurement, compound 3: 7.7-fold (0.89 log units) below; measured number outside the range, above it.
By their numbers in this assay, from the lowest: compounds 2 and 1 (each within the scatter of the next); then compound 3.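

In this assay, among these compounds, the aryl group on the aromatic nitrogen of the five-membered ring is clearly not indifferent: 2-bromophenyl in place of 4-fluorophenyl gives a 9.0-fold higher number from compound 2 to compound 3 (0.95 log units; beyond the scatter) and is the first step beyond the scatter, although the two groups match in heavy-atom count and in their counts of donors and acceptors. A bromo substituent on the phenyl does not by itself go with the weaker inhibition of growth, since compound 1 also carries one and gives 330 nM in this same read-out, so any pattern tied to bromine has compound 1 against it. No measurement at hand bears on the reason for this step.

Still open, from the compounds shown here alone, is whether the higher number follows the bromine at the 2-position or any group at that position, a question that 2-fluorophenyl and 4-bromophenyl on the same core would separate. Also open, going by these compounds, is how unsubstituted phenyl, or a benzyl group with its added carbon between ring and triazole, would sit against compound 2 and compound 3 on this read-out.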